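The source may report more compounds than this note shows. Statements on the series, on what has been measured and on what is new or still open speak of the compounds shown alone.

Compound 1 `O[C@@]1(c2ccccn2)CC[C@@H](c2ccc(C(F)(F)F)cc2)C1` gives 240 nM in an assay on HEK293 cells for antagonist activity at transient receptor potential cation channel subfamily V member 3 (Homo sapiens), read by FLIPR and calcium flux; on this read-out higher numbers stand for weaker inhibition and lower numbers for stronger inhibition; compound 2 `O[C@]1(c2ccccn2)CC[C@@H](c2ccc(C(F)(F)F)cc2)C1` gives 130 nM; compound 3 `O[C@H](c1ccccn1)C1(c2cccc(OC(F)(F)F)c2)CCC1` gives 80 nM.

Compound 2 stands second highest of the three numbers, within the scatter of compound 3 on one side and of compound 1 on the other. Compound 4 `O[C@@]1(c2ccccn2)CC[C@H](c2ccc(C(F)(F)F)cc2)C1` has not yet been measured. Against compound 2 the change is this: the two compounds have the same atoms and bonds and differ only in configuration as drawn: 2 of 2 stereo elements differ (all stereocentres are inverted: mirror images); a stereocentre at a saturated ring carbon is drawn R in compound 2 and S in compound 4; a stereocentre at a saturated ring carbon is drawn R in compound 2 and S in compound 4. Going by the values given here, only one measured step concerns configuration, a 1.8-fold lower number from compound 1 to compound 2 (0.27 log units; within the scatter), and it rests on (the fact that compounds 1 and 2 differ only in the configuration as drawn). Among the compounds with values here, no measured pair inverts every stereocentre, so that step says little about a full mirror image. The step of a 2.3-fold higher number from compound 2 to compound 4 (0.36 log units; beyond the scatter) is therefore expected to be modest but uncertain. Compound 4 is estimated at 300 nM, with a range from 80 nM to 1500 nM.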

Compound 4, antagonist equilibrium constant: 610 nM
Compound 4: middle estimate off by 2.0-fold (0.31 log units), on the low side, and the stated range covers the measured number.
By their numbers in this assay, from the lowest: compounds 3, 2 and 1 (each within the scatter of the next, the first and the last beyond it); then compound 4.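

Compound 2 and compound 1 had differed within the scatter, so configuration had not yet been shown to matter in this assay. Here it does: inverting the other saturated ring carbon stereocentre gives a 2.5-fold higher number from compound 1 to compound 4 (0.41 log units; beyond the scatter), and the full mirror image gives a 4.7-fold higher number from compound 2 to compound 4 (0.67 log units; beyond the scatter). Both steps lie beyond the scatter and can be put down to configuration alone: the fact that compounds 1 and 4 differ only in the configuration as drawn

The mirror image of compound 1 lies outside the compounds shown, so the set of stereoisomers is incomplete. As far as these compounds go, whether an amine in place of the hydroxyl group would show the same dependence on configuration also stays open.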